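The source may hold more compounds than are shown below. What is called first, only, known or untested is meant among the compounds shown, and "the series" means these compounds.

Measured compounds in an ADME assay on Vero cells (Chlorocebus sabaeus) for cytotoxicity; a higher number here means that more compound is tolerated, a lower number that less compound is tolerated:
- compound 2, `Fc1ccc(-c2nn3c(NC4CCCC4)cccc3c2-c2cc[nH]n2)cc1`: 14000 nM
- compound 3, `Fc1ccc(-c2nn3c(NC4CCCC4)cccc3c2-c2ccnc(NC3CCCC3)n2)cc1`: > 160000 nM
- compound 1, `Fc1ccc(-c2nn3c(NC4CCCC4)cccc3c2-c2cccnc2F)cc1`: "not determined" (no result reported)

For the measured compounds named here, compound 2 carries the only single number in this assay. Compound 3 sits at a limit of the assay, (the limit of > 160000 nM in this assay, at which 1 of the 3 values shown sits), so no number is known for it. Compound 1 has no result. Compound 4, `Fc1ccc(-c2nn3c(NC4CCCC4)cccc3c2-c2c[nH]c(NC3CCCC3)n2)cc1`, is yet to be measured; it differs from compound 2 by 2-(cyclopentylamino)-1H-imidazol-4-yl in place of 1H-pyrazol-3-yl on an aromatic carbon. Going by the values given here, no step between two measured compounds exists for comparison. For compound 4 the step from compound 2 is expected to run upward, toward more compound tolerated, a 4.3-fold higher number from compound 2 to compound 4 (0.63 log units; beyond the scatter), beyond the scatter. Compound 4 is therefore estimated at 60000 nM in this assay, between 15000 nM and 200000 nM.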

Compound 4, half-maximal cytotoxic concentration: 40000 nM
For compound 4 the middle estimate is 1.5-fold (0.18 log units) above the measured one; the range from low to high includes it.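

In this assay, for the compounds shown here, 2-(cyclopentylamino)-1H-imidazol-4-yl in place of 1H-pyrazol-3-yl, on the aromatic carbon next to the ring atom that bears the 4-fluorophenyl group, gives a 2.9-fold higher number from compound 2 to compound 4 (0.46 log units; beyond the scatter), the first readable step at this position. The larger group therefore comes with a modest rise in the tolerated concentration, not a drop. Nothing measured here points to a cause for this step. The value of compound 3 is only a limit, so its distance from compound 4 cannot be read. On these data alone, whether the rise follows the cyclopentylamino group or the imidazole ring stays open, as does the effect of a dimethylamino group or a carboxylic acid on that ring.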